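Vinyl on the Small Ring: A Step From Compound 3

This account rests on a few compounds, and the source may have more. Where it says the series, first, only, none or still open, it means among the compounds named here.

Measured so far, all in a functional assay on PC-3 cells (Homo sapiens) for cytotoxicity, read by MTT assay, with a stated time of 48 h; on this read-out lower numbers stand for stronger inhibition and higher numbers for weaker inhibition:
- Compound 1, `Oc1ccc(-c2nc(-c3c[nH]c4ccccc34)co2)cc1`, gives 382000 nM.
- Compound 2, `c1ccc2c(-c3coc(-c4ccncc4)n3)c[nH]c2c1`, gives 298000 nM.
- Compound 3, `c1ccc2c(-c3cocn3)c[nH]c2c1`, gives 321000 nM.

Compound 3 stands second highest of the three numbers; its nearest neighbour is compound 2 and its furthest is compound 1, and every gap among the three is within the scatter, so none of them can be called more or less active than another.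

Compound 4, `C=Cc1nc(-c2c[nH]c3ccccc23)co1`, differs from compound 3 by one change: vinyl in place of hydrogen on an aromatic carbon. It sits on the same carbon of the five-membered aromatic ring with 1 nitrogen and 1 oxygen that carries 4-hydroxyphenyl in compound 1 and pyridin-4-yl in compound 2.

Among the measured compounds shown here, two measured steps bear on that position. Removing 4-hydroxyphenyl gave a 1.2-fold lower number from compound 1 to compound 3 (0.08 log units; within the scatter), and removing pyridin-4-yl gave a 1.1-fold higher number from compound 2 to compound 3 (0.03 log units; within the scatter). Both show that groups of quite different kind at this carbon left the read-out essentially unchanged. A vinyl group is smaller than either, so no shift beyond the scatter in this assay is expected in either direction.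

The estimated step is therefore a 1.0-fold lower number from compound 3 to compound 4 (0.00 log units; within the scatter), and compound 4 is expected to give about 320000 nM, with a likely range from 150000 nM to 650000 nM.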

Compound 4, half-maximal inhibitory concentration: 426000 nM
For compound 4 the middle estimate is 1.3-fold (0.12 log units) below the measured one, within the range that was stated.
By their numbers in this assay, from the lowest: compounds 2, 3, 1 and 4 (each within the scatter of the next).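

Until now this carbon had carried only hydrogen or a ring group, and vinyl adds a small group with no ring, 2 carbon atoms and 1 double bond outside aromatic rings; in this assay the step stays within the scatter (a 1.3-fold higher number from compound 3 to compound 4 (0.12 log units; within the scatter)). Set against the two ring groups, vinyl again gives no difference that can be told from the scatter, whether it replaces pyridin-4-yl (a 1.4-fold higher number from compound 2 to compound 4 (0.16 log units; within the scatter)) or 4-hydroxyphenyl (a 1.1-fold higher number from compound 1 to compound 4 (0.05 log units; within the scatter)), so hydrogen, vinyl, pyridin-4-yl and 4-hydroxyphenyl cannot be ranked at this carbon in these four compounds. No measurement offered here gives a reason for this flat result.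

As far as these compounds go, what remains open is whether any group at this carbon can move the number beyond the scatter, for example an amine, a carboxylic acid or a longer chain such as hexyl. Also open, from the compounds shown here alone, is whether a change elsewhere on the shared core would do so, since all four compounds differ only at this one carbon.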